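A few compounds are considered here, and "the series" means these few. Any claim that something is new, unique, unknown or untested is made for them only; others in the source may bear on it.

Measured compounds in an assay for inhibition of 15-hydroxyprostaglandin dehydrogenase [NAD(+)] (Homo sapiens), read by fluorescence and spectrophotometry; on this read-out lower numbers stand for stronger inhibition and higher numbers for weaker inhibition:
- compound 1, `O=C1NC(=O)/C(=C/c2ccc(OCc3ccc([N+](=O)[O-])cc3)cc2Cl)S1`: 4540 nM
- compound 2, `O=C1NC(=O)/C(=C/c2ccc(OCCC3CCCC3)cc2Cl)S1`: 42 nM
- compound 3, `Cc1ncsc1CCOc1ccc(/C=C2\SC(=O)NC2=O)cc1Cl`: 5170 nM

Compound 3 carries the highest of the three numbers, but compound 1 sits right beside it and the two are within the usual scatter, so no order between them is claimed. Compound 2 lies far below both, well beyond the scatter; it is the only one of the three with a carbocyclic chain on the aryl ether oxygen, whereas compound 1 and compound 3 carry aromatic rings there.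

Compound 4, `O=C1NC(=O)/C(=C/c2ccc(OCC3CCC3)c(Cl)c2)S1`, has not been measured. The change from compound 3 is cyclobutyl in place of (4-methyl-1,3-thiazol-5-yl)methyl on a saturated chain carbon bound to an oxygen on an aromatic ring. It brings compound 4 closer to the type of side chain seen in compound 2 than to those of compound 1 and compound 3, although the ring is smaller and the chain shorter than in compound 2. A step well beyond the scatter toward a lower number is expected, estimated as a 21-fold lower number from compound 3 to compound 4 (1.32 log units; beyond the scatter), because compound 2 with its carbocyclic chain gives 42 nM in this assay. Going by the values given here, compound 4 is estimated at 250 nM, with a range from 40 nM to 1600 nM, the wide range reflecting that no measured pair isolates this change.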

Compound 4, half-maximal inhibitory concentration: 9 nM
Compound 4: the middle estimate sits 28-fold (1.44 log units) above what was measured; measured number outside the range, below it.
By their numbers in this assay, from the lowest: compound 4; then compound 2; then compounds 1 and 3 (each within the scatter of the next).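

Working from the side chain on a saturated chain carbon bound to an oxygen on an aromatic ring, placing cyclobutyl in place of (4-methyl-1,3-thiazol-5-yl)methyl gives a 570-fold lower number from compound 3 to compound 4 (2.76 log units; beyond the scatter) in this assay, the first step in the series that isolates a single place. This place therefore has a large effect on the read-out, and a four-membered non-aromatic ring of carbon only is compatible with a low number. Nothing available accounts for the size of this step.

The change removes the aromatic ring and its hetero atoms together and also alters ring size, so the step cannot assign the gain to any one of these. A phenyl group on the same chain, or a cyclohexyl ring or an amine-bearing cyclobutyl group in this place, would separate these contributions.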